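The source may report more compounds than this note shows. Statements on the series, on what has been measured and on what is new or still open speak of the compounds shown alone.

Measured so far in a functional assay on MDA-MB-231 cells (Homo sapiens) for antiproliferative activity, read by MTT assay, with a stated time of 24 h; on this read-out higher numbers stand for weaker inhibition and lower numbers for stronger inhibition:
- Compound 1 `Cc1ccccc1NNC(=O)c1ccc(NS(=O)(=O)c2cnc(O)nc2O)cc1`: > 20000 nM, a limit and not a number
- Compound 2 `O=C(NNc1cccc(Cl)c1)c1ccc(NS(=O)(=O)c2cnc(O)nc2O)cc1`: 17400 nM
- Compound 3 `CCCCOc1ccc(C(=O)NNC(=O)c2ccc(NS(=O)(=O)c3cnc(O)nc3O)cc2)cc1`: 11900 nM

Going by the values given here, compound 3 is one of only two compounds here with a true number. Its value and that of compound 2 lie within the usual scatter of each other, so the data cannot rank one above the other.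

The next compound, compound 4 `O=C(NNC(=O)c1ccccc1Cl)c1ccc(NS(=O)(=O)c2cnc(O)nc2O)cc1`, keeps the shared core but carries 2-chlorophenyl in place of 4-butoxyphenyl on a carbonyl carbon.

Among the compounds with values here, only one measured step is available, an at least 1.1-fold lower number from compound 1 to compound 2 (0.06 log units; that floor lies within the scatter). It lies within the scatter and swaps a group on an amine nitrogen, a different place from this change, so it offers only loose guidance. Within the data shown here, no measured step touches the group on the carbonyl carbon. Compound 1 shows (the limit of > 20000 nM in this assay, at which 1 of the 3 values shown sits). A reading at that limit therefore remains possible for compound 4.

With compound 3 at 11900 nM as the starting point, no shift beyond the scatter is expected in this assay. The estimated change is a 1.3-fold higher number from compound 3 to compound 4 (0.10 log units; within the scatter). For compound 4 the estimated value is 15000 nM, with an expected range of 7000 nM to 30000 nM.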

Compound 4, half-maximal inhibitory concentration: 13900 nM
Estimate against measurement, compound 4: 1.1-fold (0.03 log units) above; measured number inside the range.
By their numbers in this assay, from the lowest: compounds 3, 4 and 2 (each within the scatter of the next). At a limit, above all of these: compound 1.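

In this assay, the first change shown at this carbonyl carbon removes the 4-butoxyphenyl with its butyl chain and ether oxygen and brings in 2-chlorophenyl, and the result is only a 1.2-fold higher number from compound 3 to compound 4 (0.07 log units; within the scatter) and so gives no sign that the assay separates these two groups. Measured from the amine nitrogen, the exchange of 3-chlorophenyl for (2-chlorophenyl)carbonyl gives a 1.3-fold lower number from compound 2 to compound 4 (0.10 log units; within the scatter) and likewise separates nothing, so three compounds with true numbers now sit within the scatter of one another despite their different groups. The third step rests on a limit and not a number, so an at least 1.4-fold lower number from compound 1 to compound 4 (0.15 log units; that floor lies within the scatter) gives only a floor, and one compound alone still sits at that limit: the limit of > 20000 nM in this assay, at which 1 of the 4 values shown sits.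

The two groups at the carbonyl carbon differ in more than one feature, so these compounds cannot show whether the chlorine, the butyl chain or the ether oxygen matters on its own. As far as these compounds go, it also remains open whether an amine, a carboxylic acid or a longer chain on that ring would move the number beyond the scatter.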